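The source may hold more compounds than are shown below. What is called first, only, known or untested is meant among the compounds shown, and "the series" means these compounds.

Compound 1 `CC1=C(C(=O)OC(C)C)C(C2CCCC2)N/C(=N/C#N)N1` is the reference point of the set. In an assay on HeLa cells for displacement of a labelled ligand from adenosine receptor A3 (Homo sapiens), with a stated time of 180 min, tested at 1 uM (on this read-out higher numbers stand for more inhibition at the one concentration tested (going by the name of the read-out) and lower numbers for less inhibition), compound 1 gives 3%, the lowest of the three numbers recorded. Compound 2 `CC1=C(C(=O)OC(C)C)[C@@H](c2ccco2)N/C(=N/C#N)N1` gives 4%, a figure within the usual scatter of the number for compound 1. Compound 3 `CCOC(=O)C1=C(C)N/C(=N\C#N)NC1c1ccco1` gives 20%, which lies beyond the scatter above compound 1. Compound 4 `CC1=C(C(=O)OC(C)C)C(c2ccccc2)N/C(=N/C#N)N1` has not yet been measured. It differs from compound 1 in one place: phenyl in place of cyclopentyl on a saturated ring carbon. Among the compounds with values here, no measured pair covers a change of this kind, so nothing in the data sets its size. The step of a number 5 percentage points higher from compound 1 to compound 4 (within the scatter) is expected to be small, with no direction beyond the scatter anticipated. For compound 4 the estimate is 8%, with a range from 0% to 25%.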

Compound 4, a percentage reported as inhibition, at one concentration (the size of the read-out at that concentration, not a potency): 6%
Compound 4: middle estimate off by 2 percentage points, on the high side; low and high end bracket the measured number.
By their numbers in this assay, from the lowest: compounds 1, 2 and 4 (each within the scatter of the next); then compound 3.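

Within the data shown here, on the saturated ring carbon next to the ring nitrogen, phenyl in place of cyclopentyl gives in this assay a number 3 percentage points higher from compound 1 to compound 4 (within the scatter), the first single change that can be read. At this position, this read-out does not separate the aromatic carbon ring from the saturated one. No measurement shown here offers an explanation of this step.

As far as these compounds go, whether a phenyl bearing an amine or a carboxylic acid would leave the number within the scatter remains open. The same holds for a pyridyl ring or a longer alkyl chain at this ring carbon.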